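A few compounds are considered here, and "the series" means these few. Any claim that something is new, unique, unknown or untested is made for them only; others in the source may bear on it.

Measured so far:
compound 1 `COc1ccc(Nc2cc(/C=C/c3ccccc3)oc(=O)c2)cc1`: 0.11 uM
compound 2 `O=c1cc(Nc2ccc(Br)cc2)cc(-c2ccccc2)o1`: 0.31 uM

In a functional assay on A549 cells (Homo sapiens) for cytotoxicity, read by MTT assay, with a stated time of 72 h (a higher number here means that more compound is needed for the effect, a lower number that less compound is needed), compound 1 gives 0.11 uM and compound 2 gives 0.31 uM. Compound 2 therefore stands at the higher of the two numbers, and its gap to compound 1 lies beyond the scatter. Within the data shown here, compound 1 and compound 2 differ in more than one place, so no single step joins them, and the two values only show that more compound 2 than compound 1 is needed for the effect.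

Compound 3 `O=c1cc(NC2CC2)cc(-c2ccccc2)o1` is not yet measured. It differs from compound 2 in one place: cyclopropyl in place of 4-bromophenyl on a nitrogen on an aromatic ring. Among the measured compounds shown here, no measured pair shows this change, so nothing here sets its size directly. The expectation is that in this assay the step from compound 2 to compound 3 runs upward, beyond the scatter, as an 8.1-fold higher number from compound 2 to compound 3 (0.91 log units; beyond the scatter). Compound 3 is accordingly estimated at 2.5 uM, with a range from 0.6 uM to 10 uM.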

Compound 3, concentration for half-maximal effect: > 30 uM
Compound 3 ended at the assay's limit (the forecaster's own chance of this, stated with the estimate: 10%); middle value at least 12-fold (1.07 log units) away from the limit.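

Compound 3 gives > 30 uM in this assay, and this is a limit of the assay, not a number. Among these compounds, the first single-place step, cyclopropyl in place of 4-bromophenyl on a nitrogen on an aromatic ring, is an at least 96-fold higher number from compound 2 to compound 3 (1.98 log units; beyond the scatter), so the group on this nitrogen strongly affects the amount of compound needed, at least for this pair. The full size of the step cannot be read from the limit: the limit of > 30 uM in this assay, at which 1 of the 3 values shown sits.

One pair cannot separate the loss of the six-membered aromatic ring from the loss of the bromine, nor show whether the step depends on the rest of the core. On these data alone, it remains open how this assay responds to an unsubstituted phenyl, a benzyl group or a straight butyl chain on this nitrogen.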